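The source may hold more compounds than are shown below. What is called first, only, known or untested is meant among the compounds shown, and "the series" means these compounds.

Compound 1, `CSCc1ccc(Nc2ncc(Cc3c(F)cccc3F)o2)cc1`, gives > 100000 nM in an ADME assay on MT2 cells (Homo sapiens) for cytotoxicity, read by MTT assay; on this read-out lower numbers stand for higher toxicity in this test and higher numbers for lower toxicity in this test.
Compound 2, `Clc1cccc(Cl)c1Cc1nnc(Nc2ccc(COCc3ccccn3)cc2)o1`, gives > 100000 nM in this assay.
Compound 3, `[O-][n+]1ccc(OCc2ccc(Nc3ncc(Cc4c(F)cccc4F)o3)cc2Cl)cc1`, gives 1700 nM in this assay.

The value of compound 1 is a limit of this assay and not a number. Compound 2 likewise reports only a limit. Going by the values given here, compound 3 is the one compound here with a numerical value. Compound 1 therefore stands at the limit of > 100000 nM in this assay, at which 2 of the 3 values shown sit, with nothing measured that sets it apart from compound 2 in this respect.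

Compound 4, `COCc1ccc(Nc2ncc(Cc3c(F)cccc3F)o2)cc1`, has not yet been measured in this assay. It differs from compound 1 in one place: methoxy in place of methylsulfanyl on a saturated chain carbon bound to an aromatic carbon. Among the compounds with values here, no pair of measured compounds differing in one place is available, so no measured step can be pointed to for this change. Given that compound 1 sits at the limit, the step from compound 1 to compound 4 is expected to be none beyond the usual scatter, as a number no higher from compound 1 to compound 4 (the limit leaves the size open). Compound 4 is accordingly expected to give 100000 nM in this assay, estimated between 30000 nM and 300000 nM, with a good chance that only a limit is reported.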

Compound 4, half-maximal cytotoxic concentration: 32000 nM
Compound 4: the middle estimate sits 3.1-fold (0.49 log units) above what was measured, and the stated range covers the measured number.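

In this assay, going by these compounds alone, methoxy in place of methylsulfanyl on a saturated chain carbon bound to an aromatic carbon gives the one readable step at this place: an at least 3.1-fold lower number from compound 1 to compound 4 (0.49 log units; beyond the scatter). Within the data shown here, compound 4 gives 32000 nM, a real number, so this exchange of one atom in the chain is enough to bring the read-out within the measurable range, which the earlier compounds could not show for this place. The value of compound 1 is a limit and not a number, so the step has a lower bound but no full size, and that limit is shared with another compound: the limit of > 100000 nM in this assay, at which 2 of the 4 values shown sit.

The compounds shown leave open how an amine or a longer chain such as ethoxy would read at this place. They also leave open whether the same exchange would produce a similar step on a different core.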